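A few compounds are considered here, and "the series" means these few. Any claim that something is new, unique, unknown or untested is made for them only; others in the source may bear on it.

Among the compounds with values here, in a functional assay on KB cells (Homo sapiens) for cytotoxicity, read by MTT assay, with a stated time of 72 h (on this read-out higher numbers stand for weaker inhibition and lower numbers for stronger inhibition), compound 2 `Cc1ccc(S(=O)(=O)c2nc3ccccc3nc2N2CCC(O)CC2)cc1` gives 6140 nM, the only actual number so far. Compound 1 `COc1ccc(S(=O)(=O)c2nc3ccccc3nc2N2CCc3ccccc3C2)cc1` records > 50000 nM, which is a limit and not a number. Compound 3 `COc1ccc(S(=O)(=O)c2nc3ccccc3nc2N2CCC(O)CC2)cc1` keeps the shared core and the remaining groups of compound 2 and changes one place: methoxy in place of methyl on an aromatic carbon. This is methoxy in place of methyl on an aromatic carbon, para to a large group. Within the data shown here, no measured pair isolates this change, so its size cannot be read from the data. With compound 2 at 6140 nM as the sole anchor, the working expectation is no change beyond the scatter, in either direction. The expected step is small: a 1.1-fold lower number from compound 2 to compound 3 (0.05 log units; within the scatter). For compound 3 the estimated value is 5500 nM, with an expected range of 2000 nM to 15000 nM.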

Compound 3, half-maximal inhibitory concentration: 8060 nM
The estimate for compound 3 lay 1.5-fold (0.17 log units) below the measured number; the measured number falls inside the stated range.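

In this assay the change of methoxy in place of methyl on an aromatic carbon, para to a large group, gives a 1.3-fold higher number from compound 2 to compound 3 (0.12 log units; within the scatter) and so does not separate the two compounds while 4-hydroxypiperidin-1-yl stays fixed. Within the data shown here, compound 3 also gives the first step at the other place, where 4-hydroxypiperidin-1-yl in place of 1,2,3,4-tetrahydroisoquinolin-2-yl with 4-methoxyphenyl held fixed gives an at least 6.2-fold lower number from compound 1 to compound 3 (0.79 log units; beyond the scatter) and so matters more in this small set than the change on the aromatic ring. Compound 1 records > 50000 nM, which is a limit, so the step from it fixes only a minimum size: the limit of > 50000 nM in this assay, at which 1 of the 3 values shown sits.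

As far as these compounds go, whether a chlorine, a carboxylic acid or an amine at the aromatic position would move the number beyond the scatter stays open. Also open, from the compounds shown here alone, is whether the methyl and methoxy groups would stay within the scatter of each other with 1,2,3,4-tetrahydroisoquinolin-2-yl in place.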